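Swapping chloro for methoxy on the weakest compound

This account rests on a few compounds, and the source may have more. Where it says the series, first, only, none or still open, it means among the compounds named here.

Compound 1 `COc1ccc(/C=C2\CCC/C(=C\c3cccc(O)c3)C2=O)cc1OC` gives 2900 nM in cytotoxicity testing
Compound 2 `COc1ccc(/C=C2\CCC/C(=C\c3cc(Cl)cc(Cl)c3)C2=O)cc1OC` gives 3800 nM in cytotoxicity testing
Compound 3 `COc1ccc(/C=C2\CCC/C(=C\c3ccc(O)c(Cl)c3)C2=O)cc1OC` gives 12300 nM in cytotoxicity testing

All three numbers come from a functional assay on MCF7 cells (Homo sapiens) for cytotoxicity, read by MTT assay, with a stated time of 72 h (a lower number here means a stronger inhibitor, a higher number a weaker inhibitor), and the compounds differ only in one substituted phenyl group on the shared core. Compound 3 has the highest number of the three, so it is the weakest inhibitor here. The other two do not separate, since a 1.3-fold higher number from compound 1 to compound 2 (0.12 log units; within the scatter) is a step within the scatter.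

The next compound is compound 4 `COc1cc(/C=C2\CCC/C(=C\c3ccc(OC)c(OC)c3)C2=O)ccc1O` and it differs from compound 3 by methoxy in place of chloro on an aromatic carbon in one place. In words, this is methoxy in place of chloro on an aromatic carbon, ortho to a hydroxy group, giving 4-hydroxy-3-methoxyphenyl.

Going by the values given here, no measured step makes this exact swap, so the guidance is indirect. Changes to this phenyl group have so far given modest steps, namely a 4.2-fold higher number from compound 1 to compound 3 (0.63 log units; beyond the scatter) and a 3.2-fold higher number from compound 2 to compound 3 (0.51 log units; beyond the scatter) and both end at compound 3. A modest step toward a lower number is therefore expected in this assay but a step within the scatter remains possible. The estimated change is a 2.1-fold lower number from compound 3 to compound 4 (0.31 log units; beyond the scatter) and it is uncertain. For compound 4 the estimated value is 6000 nM with an expected range from 2200 nM to 16000 nM when measured.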

Compound 4, half-maximal inhibitory concentration: 7900 nM
Beside the measured number, compound 4's estimate is 1.3-fold (0.12 log units) below it, within the range that was stated.
By their numbers in this assay, from the lowest: compounds 1 and 2 (each within the scatter of the next); then compounds 4 and 3 (each within the scatter of the next).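

In this assay methoxy and chloro do not separate on an aromatic carbon ortho to a hydroxy group, since a 1.6-fold lower number from compound 3 to compound 4 (0.19 log units; within the scatter) is a step within the scatter. The higher number of compound 3 is therefore not tied to chloro alone: a 2.1-fold higher number from compound 2 to compound 4 (0.32 log units; beyond the scatter) and a 2.7-fold higher number from compound 1 to compound 4 (0.44 log units; beyond the scatter) are both modest steps beyond the scatter, so the 4-hydroxy-3-methoxyphenyl group, like the 3-chloro-4-hydroxyphenyl group, gives a higher number than the 3-hydroxyphenyl and 3,5-dichlorophenyl groups. No measurement shown here gives a reason for this shared behaviour.

The compounds shown leave open whether a quite different group at this position, such as an amine or a carboxylic acid, would move the number away from the level shared by chloro and methoxy. They also leave open how much the hydroxy group itself contributes, which a phenyl ring carrying a methoxy group in place of that hydroxy group, with the rest of the shared core unchanged, could help to show.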